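The source may hold more compounds than are shown below. What is called first, only, known or untested is meant among the compounds shown, and "the series" means these compounds.

Compound 1 `C=CS(=O)(=O)NCc1ccc(C(=O)Nc2ccc(C)c(Nc3nccc(-c4cccnc4)n3)c2)cc1`: 7710 nM
Compound 2 `C=CC(=O)Nc1cc(C(=O)Nc2ccc(C)c(Nc3nccc(-c4cccnc4)n3)c2)cc(C(F)(F)F)c1`: 5460 nM

In an ADME assay on BaF3 cells (Mus musculus) for cytotoxicity, read by CellTiter-Glo and CCK-8 assay, with a stated time of 72 h (on this read-out lower numbers stand for stronger inhibition of growth and higher numbers for weaker inhibition of growth), compound 1 gives 7710 nM and compound 2 gives 5460 nM. These values lie within the usual scatter of each other, so the two cannot be told apart. Compound 3 `CCC(=O)N(CCN(C)C)Cc1ccc(C(=O)Nc2ccc(C)c(Nc3nccc(-c4cccnc4)n3)c2)cc1` keeps the core of compound 1 but carries (2-(dimethylamino)ethyl)(propanoyl)amino in place of (vinylsulfonyl)amino on a saturated chain carbon bound to an aromatic carbon. For the measured compounds named here, no measured step shows what this swap does in this assay, so only a small shift toward a lower number is expected. The estimated change is a 1.7-fold lower number from compound 1 to compound 3 (0.23 log units; within the scatter). For compound 3 the expected value is 4500 nM, with an estimated range of 1500 nM to 11000 nM.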

Compound 3, concentration for 50% growth inhibition: > 10000 nM
Compound 3: no number, only a limit; the forecaster's own chance of this, stated with the estimate: 15%; middle value at least 2.2-fold (0.34 log units) from the limit.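

At this position on a saturated chain carbon bound to an aromatic carbon, this assay now has its first step, for (2-(dimethylamino)ethyl)(propanoyl)amino in place of (vinylsulfonyl)amino: an at least 1.2-fold higher number from compound 1 to compound 3 (0.11 log units; that floor lies within the scatter). Compound 3 gives > 10000 nM, which is a limit of the assay and not a number. The true size of the step therefore stays unknown, and its floor alone does not separate compound 3 from compound 1: the limit of > 10000 nM in this assay, at which 1 of the 3 values shown sits.

The compounds shown leave open whether a plain amine at this place would give a readable number. They also do not separate the propanoyl part of the entering group from its dimethylaminoethyl chain.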